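Swapping the Aryl Group on an Amide Nitrogen

The compounds below may be only part of what the source reports. "The series", "measured", "known", "first", "only" and "open" are said of these compounds alone.

Three compounds have been measured in a functional assay on NUGC-3 cells (Homo sapiens) for inhibition, read by sulforhodamine B assay, with a stated time of 48 h; on this read-out lower numbers stand for stronger inhibition of growth and higher numbers for weaker inhibition of growth:
compound 1 `O=C(Nc1ccc(O)cc1)C1NCCc2ccccc21` gives 4370 nM.
compound 2 `O=C(Nc1cccc(C(F)(F)F)c1)C1c2ccccc2CCN1C(=O)c1ccc(Cl)cc1` gives > 10000 nM, which is a limit of the assay rather than a number.
compound 3 `O=C(Nc1ccc(C(F)(F)F)cc1)c1nccc2ccccc12` gives > 10000 nM, again a limit and not a number.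

Compound 2 therefore stands at the weak end of what is shown: the assay reports only (the limit of > 10000 nM in this assay, at which 2 of the 3 values shown sit), so its true potency is unknown beyond that boundary, and no step between any two measured compounds can be computed here.

The unmeasured compound 4 `O=C(Nc1ccccc1O)C1c2ccccc2CCN1C(=O)c1ccc(Cl)cc1` keeps the whole of compound 2 except for one change: 2-hydroxyphenyl in place of 3-(trifluoromethyl)phenyl on an amide-type nitrogen. The 2-hydroxyphenyl group brings one hydrogen-bond donor and one hydrogen-bond acceptor where the 3-(trifluoromethyl)phenyl group had none.

Because compound 2 sits at the limit of > 10000 nM in this assay, at which 2 of the 3 values shown sit, any gain in potency would have to be large before it became visible as a number. Among the measured compounds shown here, compound 1, the only compound with a measured number, carries a hydroxyphenyl group on the same kind of amide nitrogen and gives 4370 nM, which is itself modest. The step from compound 2 to compound 4 is expected to be small, at most a slight move toward stronger growth inhibition, expressed as an at least 1.1-fold lower number from compound 2 to compound 4 (0.04 log units; that floor lies within the scatter). Compound 4 is estimated at 9000 nM, within a range from 3000 nM to 30000 nM, with a real chance that only a limit is reported again.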

Compound 4, concentration for 50% growth inhibition: > 10000 nM
Compound 4: no number, only a limit; the forecaster's own chance of this, stated with the estimate: 55%; middle value at least 1.1-fold (0.04 log units) from the limit.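

In this assay compound 4 gives > 10000 nM, which is a limit and not a number. Compound 2 also stands at a limit, so no step from compound 2 to compound 4 can be read: the limit of > 10000 nM in this assay, at which 3 of the 4 values shown sit.

The compounds shown leave open whether 2-hydroxyphenyl and 3-(trifluoromethyl)phenyl on this amide-type nitrogen differ at all in growth inhibition.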